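Toward a Phenylethyl Urea on the Spiro-Lactam Core

The compounds below may be only part of what the source reports. "The series", "measured", "known", "first", "only" and "open" are said of these compounds alone.

Compound 1 `CC[C@H](C)[C@H](NC(=O)N1CCC2(CC1)C(=O)N(c1cccc(F)c1)C2c1ccc(Cl)cc1)C(=O)NC` gives 182 nM
Compound 2 `COC(=O)[C@H](C)NC(=O)N1CCC2(CC1)C(=O)N(c1cccc(F)c1)C2c1ccc(Cl)cc1` gives 827 nM
Compound 3 `COC(=O)[C@H](CO)NC(=O)N1CCC2(CC1)C(=O)N(c1cccc(F)c1)C2c1ccc(Cl)cc1` gives 3330 nM

These three ureas share one core and differ only in the group on the urea nitrogen. In an assay on HEK293 cells for inhibition of Voltage-dependent T-type calcium channel subunit alpha-1H (Homo sapiens), read by patch clamp, using a membrane potential dye (on this read-out higher numbers stand for weaker inhibition and lower numbers for stronger inhibition), compound 3 sits at the top of the three numbers, the weakest inhibitor measured so far. The two steps that lead to it are both clear: a 4.5-fold higher number from compound 1 to compound 2 (0.66 log units; beyond the scatter) and a 4.0-fold higher number from compound 2 to compound 3 (0.60 log units; beyond the scatter); the direct comparison reads an 18-fold higher number from compound 1 to compound 3 (1.26 log units; beyond the scatter).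

Compound 4 `C[C@@H](NC(=O)N1CCC2(CC1)C(=O)N(c1cccc(F)c1)C2c1ccc(Cl)cc1)c1ccccc1` has not yet been measured. It takes (1-phenylethyl in place of 2-hydroxy-1-(methoxycarbonyl)ethyl on an amide-type nitrogen). Within the data shown here, two measured steps bear on this change. Removing the hydroxy, the reverse of the step from compound 2 to compound 3, is worth a modest gain on its own. Moving away from the small methyl ester toward a larger group, as the reverse of the step from compound 1 to compound 2 shows, was also worth a modest gain. Among the measured compounds shown here, compound 4 drops every donor and acceptor of the side chain at once, a change that no measured pair copies exactly, so the size of the step is uncertain.

Compound 4 is therefore expected to show an 8.3-fold lower number from compound 3 to compound 4 (0.92 log units; beyond the scatter), an estimated 400 nM with a range from 100 nM to 1600 nM.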

Compound 4, half-maximal inhibitory concentration: 351 nM
Compound 4: middle estimate off by 1.1-fold (0.06 log units), on the high side; measured number inside the range.
By their numbers in this assay, from the lowest: compounds 1 and 4 (each within the scatter of the next); then compound 2; then compound 3.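

In this assay, the group on the amide-type nitrogen can lose its ester and its hydroxy altogether and inhibition still improves: 1-phenylethyl, with one six-membered aromatic ring of carbon only and no hydrogen-bond donor or acceptor, gives a clear gain over both side chains that carry the ester (a 9.5-fold lower number from compound 3 to compound 4 (0.98 log units; beyond the scatter); a 2.4-fold lower number from compound 2 to compound 4 (0.37 log units; beyond the scatter)). The comparison with the remaining urea reads differently (a 1.9-fold higher number from compound 1 to compound 4 (0.29 log units; within the scatter)), so the all-carbon 1-phenylethyl and the 2-methyl-1-(methylcarbamoyl)butyl group, which keeps its carbonyl and its amide hydrogen, cannot be told apart here, and among these four compounds, hydrogen-bond donors and acceptors in this group are evidently not required for the best numbers seen. Nothing measured here gives a reason for the size of any of these steps.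

Going by these compounds, it stays open whether the aromatic ring or the branching methyl of 1-phenylethyl carries the gain, which a plain benzyl group or a cyclohexylethyl group would help to separate. The mirror-image form of 1-phenylethyl, and a side chain ending in a carboxylic acid or an amine, also remain to be placed on this scale.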